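Hydroxamate linker variation on a sulfonyl furoxan series

A few compounds are considered here, and "the series" means these few. Any claim that something is new, unique, unknown or untested is made for them only; others in the source may bear on it.

Measured compounds:
- compound 1, `O=C(CCCOc1no[n+]([O-])c1S(=O)(=O)c1ccccc1)NO`: 1480 nM
- compound 2, `CC(C)(COc1no[n+]([O-])c1S(=O)(=O)c1ccccc1)C(=O)NO`: 6080 nM
- compound 3, `O=C(/C=C/COc1no[n+]([O-])c1S(=O)(=O)c1ccccc1)NO`: "not determined" (no result reported)

All numbers come from a functional assay on KG-1 cells (Homo sapiens) for inhibition, read by MTT assay, with a stated time of 48 h; a lower number here means a stronger inhibitor, a higher number a weaker inhibitor. Compound 1 gives the lowest of the two numbers available; compound 2 sits at a 4.1-fold higher number from compound 1 to compound 2 (0.61 log units; beyond the scatter), and compound 3 has no result. Compound 4, `O=C(NO)OCCOCCOc1no[n+]([O-])c1S(=O)(=O)c1ccccc1`, has not been measured. It differs from compound 1 by 2-((hydroxycarbamoyl)oxy)ethoxy in place of (hydroxycarbamoyl)methyl on a saturated chain carbon, two bonds along the chain from an oxygen on an aromatic ring. Going by the values given here, the one measured step, a 4.1-fold higher number from compound 1 to compound 2 (0.61 log units; beyond the scatter), involves a change on the same saturated chain that carries the hydroxycarbamoyl group, and it was modest in the weakening direction; no step is available for an extended chain or for a hydroxycarbamoyl group on an oxygen rather than a carbon. The change to compound 4 is larger than that step, so a weakening of roughly similar or somewhat larger size is expected, with wide uncertainty. For compound 4 the expected value in this assay is 4000 nM, range 1200 nM to 15000 nM, which corresponds to an expected step of a 2.7-fold higher number from compound 1 to compound 4 (0.43 log units; beyond the scatter).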

Compound 4, half-maximal inhibitory concentration: 5380 nM
For compound 4 the middle estimate is 1.3-fold (0.13 log units) below the measured one; the range from low to high includes it.
By their numbers in this assay, from the lowest: compound 1; then compounds 4 and 2 (each within the scatter of the next).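

The step of a 3.6-fold higher number from compound 1 to compound 4 (0.56 log units; beyond the scatter) in this assay shows that this chain position accepts 2-((hydroxycarbamoyl)oxy)ethoxy in place of (hydroxycarbamoyl)methyl at a modest cost, and it extends the reading from a branched chain to a longer one with the hydroxycarbamoyl group on an oxygen. With a 4.1-fold higher number from compound 1 to compound 2 (0.61 log units; beyond the scatter), both readable changes to the chain of compound 1 raise the number, and no readable compound goes against this. No available data bear on the reason for the step.

That step changes chain length and the attachment of the hydroxycarbamoyl group together, so a longer all-carbon chain ending in the hydroxycarbamoyl group would be needed to separate the two. Also open, going by these compounds, is what a carboxylic acid in place of the hydroxycarbamoyl group would give.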